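Amide-linked sulfonyl series: exchange of the bicyclic acyl group

The source may hold more compounds than are shown below. What is called first, only, known or untested is meant among the compounds shown, and "the series" means these compounds.

Measured compounds:
compound 1 `Cn1c(C(=O)NCc2ccc(S(=O)(=O)c3ccccc3)cc2)cc2cnccc21`
compound 2 `O=C(Nc1ccc(S(=O)(=O)N2CCCCC2)cc1)c1cc2cnccc2[nH]1`
compound 3 `O=C(NCc1ccc(S(=O)(=O)N2CCCCC2)cc1)c1cc2cnccc2s1`

In an assay for inhibition of Nicotinamide phosphoribosyltransferase (Homo sapiens), read by mass spectrometry, with stated times of 15 min and 30 min (a higher number here means a weaker inhibitor, a lower number a stronger inhibitor), compound 1 gives only a limit, > 10000 nM. Compound 2 likewise gives only a limit, > 10000 nM. Going by the values given here, compound 3 gives 150 nM, the one real number among the three. The other two sit at the limit of > 10000 nM in this assay, at which 2 of the 3 values shown sit. Among the compounds with values here, no two measured compounds differ in a single place, so no measured step exists.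

Compound 4 `O=C(NCc1ccc(S(=O)(=O)N2CCCCC2)cc1)c1ccn2cncc2c1` is not yet measured. It differs from compound 3 by a group of 9 heavy atoms (7 carbon, 2 nitrogen; one five-membered aromatic ring with 2 hetero atoms, one six-membered aromatic ring with 1 hetero atom) in place of a group of 9 heavy atoms (7 carbon, 1 nitrogen, 1 sulfur; one five-membered aromatic ring with 1 hetero atom, one six-membered aromatic ring with 1 hetero atom), on a carbonyl carbon. Within the data shown here, with only one number in hand, the step is expected to be a loss beyond the scatter, estimated at a 4.0-fold higher number from compound 3 to compound 4 (0.60 log units; beyond the scatter). Compound 4 is therefore expected at 600 nM, within 150 nM to 3000 nM.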

Compound 4, half-maximal inhibitory concentration: 1700 nM
Compound 4: the middle estimate sits 2.8-fold (0.45 log units) below what was measured; measured number inside the range.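

In this assay the exchange on the carbonyl carbon gives an 11-fold higher number from compound 3 to compound 4 (1.05 log units; beyond the scatter), so this position responds strongly to the change of bicyclic group, even though the group leaving and the group entering match in heavy atoms, hydrogen-bond donors and hydrogen-bond acceptors. Compound 4 still gives a real number, 1700 nM, and not a limit. Nothing measured here points to a cause for this loss.

Open, as far as these compounds go, is whether a single pyridine ring on the same carbonyl carbon would hold the level of compound 3. Also open, from the compounds shown here alone, is how a methyl group on the bicyclic group of compound 3 would shift the number.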